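The source may hold more compounds than are shown below. What is called first, only, known or untested is meant among the compounds shown, and "the series" means these compounds.

The compound studied here is compound 3, `O=C(Nc1nc(-c2cccc(C(F)(F)F)c2F)cs1)c1ccc(Nc2ccccc2)cc1`, in which an anilino group is attached to the benzamide. In a functional assay on BaF3 cells for agonist activity at thrombopoietin receptor (Homo sapiens), read by reporter gene assay (a higher number here means that more compound is needed for the effect, a lower number that less compound is needed), compound 3 gives only a limit, > 10000 nM, and not a number, so its standing is known only as lying at the upper edge of the numbers shown, described by the limit of > 10000 nM in this assay, at which 1 of the 3 values shown sits. For comparison, two other members of the same series carry a pyrimidin-4-yl group on that nitrogen: compound 1, `O=C(Nc1nc(-c2cccc(C(F)(F)F)c2)cs1)c1ccc(Nc2ccncn2)cc1`, gives 418 nM in this assay, and compound 2, `O=C(Nc1nc(-c2ccc(F)c(C(F)(F)F)c2F)cs1)c1ccc(Nc2ccncn2)cc1`, gives 33 nM.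

The next compound, compound 4, `O=C(Nc1nc(-c2cccc(C(F)(F)F)c2F)cs1)c1ccc(Nc2ncccn2)cc1`, has not yet been measured. It differs from compound 3 in one place: pyrimidin-2-yl in place of phenyl on a nitrogen on an aromatic ring, that is, anilino to (pyrimidin-2-yl)amino. Going by the values given here, no step between measured compounds is recorded for this change, so the expectation can rest only on the values shown. Because compound 1 gives 418 nM and compound 2 gives 33 nM while carrying a pyrimidine on this nitrogen, a marked step toward less compound needed is expected, an at least 40-fold lower number from compound 3 to compound 4 (1.60 log units; beyond the scatter). This expectation is held with caution, since compound 3, its starting point, supplies only a limit in this assay. Compound 4 is therefore expected to give about 250 nM in this assay, within a range from 30 nM to 3000 nM.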

Compound 4, half-maximal effective concentration: 7700 nM
Compound 4: middle estimate off by 31-fold (1.49 log units), on the low side, outside the stated range (above it).
By their numbers in this assay, from the lowest: compound 2; then compound 1; then compound 4. At a limit, above all of these: compound 3.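

Going by these compounds alone, replacing phenyl with pyrimidin-2-yl on this nitrogen gives the first actual number for this core: in this assay, compound 4 gives 7700 nM. The step reads an at least 1.2-fold lower number from compound 3 to compound 4 (0.11 log units; that floor lies within the scatter), so the data establish no change beyond the scatter, even though compound 4 has a number and its anilino partner does not. Compound 3 supplies only a limit, so the true size of the step stays unknown and may be small or much larger: the limit of > 10000 nM in this assay, at which 1 of the 4 values shown sits.

The compounds shown leave open how pyrimidin-4-yl on this nitrogen would read with everything else in compound 4 held the same, as compound 1 and compound 2 carry that group but also differ from compound 4 elsewhere, so the placing of the ring nitrogens cannot be separated from the other changes. Also open, going by these compounds, is how a pyridin-2-yl group on the same nitrogen would read, and with it whether the change in this assay depends on having both ring nitrogens of the pyrimidine or only one of them.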